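The source may report more compounds than this note shows. Statements on the series, on what has been measured and on what is new or still open speak of the compounds shown alone.

Compound 3, with the structure `Cc1ccc(-c2cc(-c3ccoc3)cc(-c3ccc(Cl)s3)n2)o1`, stands highest among the three compounds measured in an assay on isolated protein for inhibition of DNA topoisomerase 1 (Homo sapiens), with a stated time of 30 min, tested at 100 uM; a lower number here means less inhibition, a higher number more inhibition at the concentration tested (going by the name of the read-out): compound 3 gives 13.2%, whereas compound 1, `Cc1ccsc1-c1cc(-c2ccco2)cc(-c2ccccc2Cl)n1`, gives 2% and compound 2, `Cc1ccsc1-c1cc(-c2ccco2)cc(-c2ccc(Cl)cc2)n1`, gives 1%. Both gaps from compound 3 are beyond the scatter. Within the data shown here, the one measured step between neighbours, a number 1 percentage points lower from compound 1 to compound 2 (within the scatter), lies within the scatter and concerns only where the chlorine sits on the phenyl ring.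

Compound 4, `Clc1cccc(-c2cc(-c3ccoc3)cc(-c3ccc(Cl)s3)n2)c1`, differs from compound 3 in one place: 3-chlorophenyl in place of 5-methylfuran-2-yl on an aromatic carbon. Among the measured compounds shown here, no measured pair shows exactly this exchange, so the step from compound 1 to compound 2 bears on it only loosely, by showing that a chlorophenyl group at this position of the core is compatible with low readings in compounds 1 and 2. Since compounds 1 and 2, which carry a chlorophenyl group next to the ring nitrogen, both sit well below compound 3, a downward step is expected for compound 4, a number 8.2 percentage points lower from compound 3 to compound 4 (within the scatter), though the other differences between those compounds and compound 4 make this uncertain. Compound 4 is therefore estimated at 5%, with a range from 0% to 20%.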

Compound 4, a percentage reported as inhibition, at one concentration (the size of the read-out at that concentration, not a potency): 2.1%
Compound 4: the middle estimate sits 2.9 percentage points above what was measured; measured number inside the range.
By their numbers in this assay, from the lowest: compounds 2, 1 and 4 (each within the scatter of the next); then compound 3.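

In this assay, putting 3-chlorophenyl in place of 5-methylfuran-2-yl on the aromatic carbon next to the ring nitrogen gives a number 11.1 percentage points lower from compound 3 to compound 4 (beyond the scatter). Among these compounds, the only earlier step moved a chlorine around a phenyl ring and left the reading unchanged within the scatter, whereas this one replaces the whole group while the 5-chlorothiophen-2-yl and furan-3-yl groups stay in place, showing that the reading of compound 3 depends on the group at this position. Nothing given here accounts for this fall.

From the compounds shown here alone, it remains open whether the furan oxygen, the methyl or the whole 5-methylfuran-2-yl group matters, which a plain phenyl or an unsubstituted furan-2-yl group could help separate. Going by these compounds, how an amine or a carboxylic acid at this position would read also remains open.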